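Moving a trifluoromethoxy group around a phenyl ring

The source may report more compounds than this note shows. Statements on the series, on what has been measured and on what is new or still open speak of the compounds shown alone.

In a functional assay on LNCaP cells (Homo sapiens) for antiproliferative activity, read by propidium iodide staining, with a stated time of 96 h (a higher number here means a weaker inhibitor, a lower number a stronger inhibitor), compound 1 `CC(O)(CS(=O)(=O)c1ccccc1C(F)(F)F)C(=O)Nc1ccc(S(F)(F)(F)(F)F)cc1` gives 10800 nM, compound 2 `CC(O)(CS(=O)(=O)c1ccc(OC(F)(F)F)cc1)C(=O)Nc1ccc(S(F)(F)(F)(F)F)cc1` gives 92800 nM and compound 3 `CC(O)(CS(=O)(=O)c1cccc(OC(F)(F)F)c1)C(=O)Nc1ccc(S(F)(F)(F)(F)F)cc1` gives 21700 nM. The data show a 4.3-fold lower number from compound 2 to compound 3 (0.63 log units; beyond the scatter), but only a 2.0-fold higher number from compound 1 to compound 3 (0.30 log units; within the scatter), so compound 3 groups with compound 1. Compound 4 `CC(O)(CS(=O)(=O)c1ccccc1OC(F)(F)F)C(=O)Nc1ccc(S(F)(F)(F)(F)F)cc1` has 2-(trifluoromethoxy)phenyl in place of 3-(trifluoromethoxy)phenyl on a sulfonyl sulfur. The step of an 8.6-fold higher number from compound 1 to compound 2 (0.93 log units; beyond the scatter) shows that swapping this aryl group can matter. The closest match is compound 1, which carries 2-(trifluoromethyl)phenyl and gives 10800 nM, so only a small fall is expected. The expected step is a 1.8-fold lower number from compound 3 to compound 4 (0.26 log units; within the scatter), probably no larger than the scatter. For compound 4 the estimated value is 12000 nM, with an expected range of 4500 nM to 30000 nM.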

Compound 4, half-maximal inhibitory concentration: 12700 nM
Compound 4: the middle estimate sits 1.1-fold (0.02 log units) below what was measured; measured number inside the range.
By their numbers in this assay, from the lowest: compounds 1, 4 and 3 (each within the scatter of the next); then compound 2.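

Compound 4 shows that the trifluoromethoxy group gives numbers that cannot be told apart with 2-(trifluoromethoxy)phenyl and 3-(trifluoromethoxy)phenyl on the sulfonyl sulfur (a 1.7-fold lower number from compound 3 to compound 4 (0.23 log units; within the scatter)). Only compound 2, with 4-(trifluoromethoxy)phenyl, stands clearly apart (a 7.3-fold lower number from compound 2 to compound 4 (0.86 log units; beyond the scatter)). Compound 4 also allows a direct comparison of trifluoromethoxy and trifluoromethyl on an aromatic carbon, and the two cannot be told apart (a 1.2-fold higher number from compound 1 to compound 4 (0.07 log units; within the scatter)).

Going by these compounds, whether a methoxy group or a chlorine atom would follow the same pattern on this phenyl ring remains open. No measurement shown here explains why compound 2 stands apart.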